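Swapping a branched chain for a ring on the core nitrogen

The source may hold more compounds than are shown below. What is called first, only, known or untested is meant among the compounds shown, and "the series" means these compounds.

Of the compounds shown here, three built on a shared core have been measured in an assay on Huh-7 cells for agonist activity at Bile acid receptor (Homo sapiens), read by a luciferase reporter; a higher number here means that more compound is needed for the effect, a lower number that less compound is needed. Compound 1 `CCC(CC)n1c(-c2ccc(OCc3c(-c4c(Cl)cccc4Cl)noc3C(C)C)cc2)nc2ccc(C(=O)O)cc21` gives 0.8 nM. Compound 3 `CCCC(CCC)n1c(-c2ccc(OCc3c(-c4c(Cl)cccc4Cl)noc3C(C)C)cc2)nc2ccc(C(=O)O)cc21`, which carries 1-propylbutyl on an aromatic nitrogen, gives 1.8 nM, the second highest of the three numbers. Compound 2 `CC(C)c1onc(-c2c(Cl)cccc2Cl)c1COc1ccc(-c2nc3ccc(C(=O)O)cc3n2CC2CCCCC2)c(F)c1`, which bears cyclohexylmethyl on that nitrogen and an extra fluorine on one ring, gives 7.8 nM.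

Going by the values given here, the only single-point step among them is a 2.3-fold higher number from compound 1 to compound 3 (0.35 log units; beyond the scatter), a modest change that comes from reshaping the chain on the nitrogen. The move to compound 4 `CC(C)c1onc(-c2c(Cl)cccc2Cl)c1COc1ccc(-c2nc3ccc(C(=O)O)cc3n2CC2CCCCC2)cc1` is cyclohexylmethyl in place of 1-propylbutyl on an aromatic nitrogen. Among the compounds with values here, compound 2 shows that cyclohexylmethyl with the added fluorine gives a higher number than compound 3, but no measured pair separates the ring change from the fluorine, so its weight is unknown. Given the modest size of the step between compound 1 and compound 3, the expected step is a 1.9-fold higher number from compound 3 to compound 4 (0.29 log units; within the scatter), a somewhat higher number. Compound 4 is therefore expected to give about 3.5 nM in this assay, within a range from 1.2 nM to 10 nM.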

Compound 4, half-maximal effective concentration: 0.52 nM
Estimate against measurement, compound 4: 6.7-fold (0.83 log units) above; the whole stated range lies above it.
By their numbers in this assay, from the lowest: compounds 4 and 1 (each within the scatter of the next); then compound 3; then compound 2.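

Compound 4 separates the two changes that compound 2 carried together. With the same count of carbon atoms on the nitrogen, closing the chain into a ring does not raise the number but gives (a 3.5-fold lower number from compound 3 to compound 4 (0.54 log units; beyond the scatter)) in this assay, and exchanging pentan-3-yl for cyclohexylmethyl leaves the two compounds level (a 1.5-fold lower number from compound 1 to compound 4 (0.19 log units; within the scatter)). The large change instead goes with the fluorine, as hydrogen in place of fluoro gives (a 15-fold lower number from compound 2 to compound 4 (1.18 log units; beyond the scatter)).

Going by these compounds, whether fluoro costs as much alongside a branched chain, and how chloro or methoxy on that aromatic carbon or cyclopentylmethyl on the nitrogen would read, stays open. Nothing shown here explains why either change moves the number as it does.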